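A few compounds are considered here, and "the series" means these few. Any claim that something is new, unique, unknown or untested is made for them only; others in the source may bear on it.

Measured so far:
compound 1 `CC(=O)N1CCC(c2cnc(NCc3c(F)ccc4c3CCO4)c3cn[nH]c(=O)c23)CC1` gives 2.9
compound 2 `Cc1nc(C(=O)N(C)C)ccc1-c1cnc(NCc2c(F)ccc3c2CCO3)c2cn[nH]c(=O)c12` gives 2.1

In a physicochemical assay for lipophilicity, using the shake flask method, in phosphate buffer, measured as octanol-water partition, with a stated time of 30 min, at pH 7.4 (on this read-out higher numbers stand for higher lipophilicity and lower numbers for lower lipophilicity), compound 2 stands lowest of the two numbers; compound 1 sits higher by a gap beyond the scatter. Compound 3 `Cc1nc(CO)ccc1-c1cnc(NCc2c(F)ccc3c2CCO3)c2cn[nH]c(=O)c12` has not yet been measured. Against compound 2 its change is hydroxymethyl in place of dimethylcarbamoyl on an aromatic carbon; no measured pair of this kind exists in the series to lean on. The change is expected to give only a small step, a number 0.10 log units higher from compound 2 to compound 3 (within the scatter), not beyond the scatter in either direction. For compound 3 the estimate in this assay is 2.2, with a range from 1.7 to 2.7.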

Compound 3, distribution coefficient: 2.4
Estimate against measurement, compound 3: 0.20 log units below; the measured number falls inside the stated range.
By their numbers in this assay, from the lowest: compounds 2 and 3 (each within the scatter of the next); then compound 1.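

In this assay, hydroxymethyl in place of dimethylcarbamoyl on the aromatic carbon next to the ring nitrogen gives a number 0.30 log units higher from compound 2 to compound 3 (within the scatter) and so does not separate the two groups at this position. 6-(Hydroxymethyl)-2-methylpyridin-3-yl in place of 1-acetylpiperidin-4-yl gives a number 0.50 log units lower from compound 1 to compound 3 (beyond the scatter) and so leaves a gap beyond the scatter between these two substituents on the shared core. No evidence at hand accounts for either step.

Still open, going by these compounds, is how an amine or a carboxylic acid on the same aromatic carbon would read against compound 3 in this assay on this scale.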